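Nitro for chloro on the outer aryl piperazine

The compounds below may be only part of what the source reports. "The series", "measured", "known", "first", "only" and "open" are said of these compounds alone.

Measured compounds in a functional assay on MCF7 cells (Homo sapiens) for cytotoxicity, read by MTT assay, with a stated time of 24 h; on this read-out lower numbers stand for stronger inhibition and higher numbers for weaker inhibition:
Compound 1, `O=C(CN1CCN(c2ccccc2Cl)CC1)N1CCN(c2nnc(-c3ccc(Cl)cc3)c(-c3ccc(Cl)cc3)n2)CC1`: compound 1 gives 396000 nM.
Compound 2, `O=C(CN1CCN(c2ccc(Cl)cc2)CC1)N1CCN(c2nnc(-c3ccc(Cl)cc3)c(-c3ccc(Cl)cc3)n2)CC1`: compound 2 gives only a limit, > 803000 nM.

Within the data shown here, compound 2 thus stands at the limit of this assay, with no number of its own; the single measured step, an at least 2.0-fold higher number from compound 1 to compound 2 (0.30 log units; that floor lies within the scatter), ends at that limit, as the limit of > 803000 nM in this assay, at which 1 of the 2 values shown sits, shows. Compound 3, `O=C(CN1CCN(c2ccc([N+](=O)[O-])cc2)CC1)N1CCN(c2nnc(-c3ccc(Cl)cc3)c(-c3ccc(Cl)cc3)n2)CC1`, differs from compound 2 by nitro in place of chloro on an aromatic carbon. Among the measured compounds shown here, no measured step touches a nitro group, and the one step on record, an at least 2.0-fold higher number from compound 1 to compound 2 (0.30 log units; that floor lies within the scatter), moved the chloro group to another aromatic carbon and only reached the limit, so it gives no guide to the size of this exchange. Compound 3 is therefore expected to sit near the limit as well, with a step of a number no higher from compound 2 to compound 3 (the limit leaves the size open) that is not expected to exceed the scatter. The estimate for compound 3 is 800000 nM, with a range from 200000 nM to 3000000 nM.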

Compound 3, half-maximal inhibitory concentration: > 789000 nM
Compound 3: no number, only a limit; the forecaster's own chance of this, stated with the estimate: 60%; the middle value is on the limit's open side.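

Nitro in place of chloro, para to a large group, again gives no number in this assay, only a limit: the limit of > 789000 nM in this assay, at which 1 of the 3 values shown sits.

Among these compounds, no step between compound 2 and compound 3 can be read, so the size of the chloro to nitro exchange stays unknown. Among the compounds shown here, the one readable new step is an at least 1.9-fold higher number from compound 1 to compound 3 (0.29 log units; that floor lies within the scatter), and with 4-nitrophenyl in place of 2-chlorophenyl it adds a second case in which a 4-substituted phenyl ends at a limit, leaving compound 1 with the only number among the three.

Going by these compounds, how far compound 2 and compound 3 lie past their limits remains open. Also open, on these data alone, is whether an amine or a carboxylic acid on this aromatic carbon would bring a readable number, and whether nitro in the place of the 2-chloro group of compound 1 would stay readable.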